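The source may report more compounds than this note shows. Statements on the series, on what has been measured and on what is new or still open speak of the compounds shown alone.

- Compound 1 `CS(=O)(=O)c1ccc(-n2nc(C(F)(F)F)cc2-c2ccccc2)nc1`: 50 ug/mL
- Compound 2 `CS(=O)(=O)c1ccc(-n2nc(C(F)(F)F)cc2NC2CCCC2)nc1`: 25 ug/mL

These two compounds are the only ones measured so far in a physicochemical assay for solubility; a higher number here means a more soluble compound, a lower number a less soluble compound. For the measured compounds named here, compound 2 gives 25 ug/mL, and its one measured step, a 2.0-fold lower number from compound 1 to compound 2 (0.30 log units; within the scatter), shows that it cannot be told apart from compound 1. The next compound to be measured is compound 3 `CC(C)COc1cc(C(F)(F)F)nn1-c1ccc(S(C)(=O)=O)cn1`, which has isobutoxy in place of cyclopentylamino on an aromatic carbon. The measured step also exchanged the group on that carbon, with cyclopentylamino in place of phenyl, and it stayed within the scatter. A single step is thin evidence, but it gives no reason to expect a change beyond the scatter in this assay. The expected result is no change at the digits printed from compound 2 to compound 3 (within the scatter). Compound 3 is estimated at 25 ug/mL, with an expected range of 8 ug/mL to 70 ug/mL.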

Compound 3, solubility: 50 ug/mL
Estimate against measurement, compound 3: 2.0-fold (0.30 log units) below; low and high end bracket the measured number.
By their numbers in this assay, from the lowest: compounds 2, 1 and 3 (each within the scatter of the next).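

In this assay, this aromatic carbon now carries a third kind of group: isobutoxy, which has no ring, alongside the ring-bearing phenyl and cyclopentylamino. Isobutoxy in place of cyclopentylamino, which also removes the one hydrogen-bond donor, gives a 2.0-fold higher number from compound 2 to compound 3 (0.30 log units; within the scatter), and isobutoxy in place of phenyl gives no change at the digits printed from compound 1 to compound 3 (within the scatter). Across these three compounds, then, neither losing the ring nor losing that donor takes the read-out beyond the scatter, so the three cannot be told apart at this position.

No evidence at hand bears on this result. On these data alone, whether a carboxylic acid or a longer chain on this carbon would move the number beyond the scatter stays open, as does whether changes elsewhere on the shared core would do so.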